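Swapping the aryl group on the core toward compound 4

The source may report more compounds than this note shows. Statements on the series, on what has been measured and on what is new or still open speak of the compounds shown alone.

Three compounds share one core and differ in the aryl group on an aromatic nitrogen and in a fluorine on the central ring. Compound 1 `O=C(Nc1ccc(Oc2ccnc3[nH]ccc23)cc1)c1cc2cccnc2n(-c2ccc(C(F)(F)F)cc2Cl)c1=O` gives 2160 nM in a functional assay on HT-29 cells (Homo sapiens) for antiproliferative activity, read by MTT assay, with a stated time of 72 h; on this read-out lower numbers stand for stronger inhibition and higher numbers for weaker inhibition. Compound 2 `O=C(Nc1ccc(Oc2ccnc3[nH]ccc23)c(F)c1)c1cc2cccnc2n(-c2ccc(F)c(Cl)c2)c1=O` gives 310 nM, and compound 3 `O=C(Nc1ccc(Oc2ccnc3[nH]ccc23)c(F)c1)c1cc2cccnc2n(-c2ccc(Br)cc2F)c1=O` gives 820 nM. Compound 3 therefore stands second highest of the three numbers, sitting between compound 1 and compound 2 on either side.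

For the measured compounds named here, the one measured step that changes this aryl group, a 2.6-fold higher number from compound 2 to compound 3 (0.42 log units; beyond the scatter), shows that swapping it moves the read-out by a modest amount.

Compound 4 `O=C(Nc1ccc(Oc2ccnc3[nH]ccc23)c(F)c1)c1cc2cccnc2n(-c2ccc(C(F)(F)F)cc2Cl)c1=O` is the next step: 2-chloro-4-(trifluoromethyl)phenyl in place of 4-bromo-2-fluorophenyl on an aromatic nitrogen. Compound 1 carries this same 2-chloro-4-(trifluoromethyl)phenyl group, though without the fluorine on the central ring, and its value sits well above that of compound 3. On that basis a modest shift upward is expected, of about a 1.8-fold higher number from compound 3 to compound 4 (0.26 log units; within the scatter), with the size uncertain because the fluorine on the central ring is not isolated in any measured step. Compound 4 is estimated at 1500 nM in this assay, within a range from 500 nM to 4500 nM.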

Compound 4, half-maximal inhibitory concentration: 1360 nM
Estimate against measurement, compound 4: 1.1-fold (0.04 log units) above; measured number inside the range.
By their numbers in this assay, from the lowest: compound 2; then compounds 3, 4 and 1 (each within the scatter of the next, the first and the last beyond it).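

In this assay, placing 2-chloro-4-(trifluoromethyl)phenyl in place of 4-bromo-2-fluorophenyl on the aromatic nitrogen gives a 1.7-fold higher number from compound 3 to compound 4 (0.22 log units; within the scatter) and so does not separate these two aryl groups. For the compounds shown here, the same group does separate from 3-chloro-4-fluorophenyl, with a 4.4-fold higher number from compound 2 to compound 4 (0.64 log units; beyond the scatter) as the step, so among the three aryl groups paired with the fluorine on the central ring, the one in compound 2 gives the lowest number, beyond the scatter of both others. Going by these compounds alone, the central-ring fluorine can now be read alone for the first time, and a 1.6-fold lower number from compound 1 to compound 4 (0.20 log units; within the scatter) shows that adding it to an aromatic carbon makes no difference that can be told from the scatter when 2-chloro-4-(trifluoromethyl)phenyl sits on the nitrogen.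

No measurement at hand explains why the aryl groups differ. Still open, on these data alone, is how the number would respond to an aryl group carrying an amine or a carboxylic acid, or to a plain alkyl chain on this nitrogen, and whether the central-ring fluorine would matter as little alongside 3-chloro-4-fluorophenyl.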